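Methyl on an Aromatic Oxygen: Two Parallel Steps

A few compounds are considered here, and "the series" means these few. Any claim that something is new, unique, unknown or untested is made for them only; others in the source may bear on it.

Three compounds have been measured in a functional assay on HCT-116 cells (Homo sapiens) for antiproliferative activity, read by MTT assay, with a stated time of 72 h; on this read-out lower numbers stand for stronger inhibition and higher numbers for weaker inhibition:
compound 1 `C=CC(=O)Nc1nc(-c2ccc(OC)cc2)cs1` gives 8000 nM
compound 3 `C=CC(=O)Nc1nc(-c2ccc(O)cc2)cs1` gives 7100 nM
compound 2 `C=CC(=O)Nc1nc(-c2ccccc2O)cs1` gives > 30000 nM, which is a limit of the assay and not a number.

Compound 3 and compound 1 differ by methyl in place of hydrogen on an oxygen on an aromatic ring, and that step produced a 1.1-fold higher number from compound 3 to compound 1 (0.05 log units; within the scatter). Compound 2 has the same atoms as compound 3 joined differently; the difference between the two cores is not broken down here. Of compound 2 only the limit of > 30000 nM in this assay, at which 1 of the 3 values shown sits, is known.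

Compound 4 `C=CC(=O)Nc1nc(-c2ccccc2OC)cs1` has not yet been measured. It differs from compound 2 by methyl in place of hydrogen on an oxygen on an aromatic ring, the same change that was made from compound 3 to compound 1, at a place described in the same words. The expected step in this assay is a number no higher from compound 2 to compound 4 (the limit leaves the size open), resting on the earlier pair, where the measured change stayed within the scatter, and on the fact that the starting point, compound 2, is only a limit. Compound 4 is therefore expected to give about 30000 nM, estimated between 15000 nM and 60000 nM, with a real chance that the assay again reports only a limit.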

Compound 4, half-maximal inhibitory concentration: > 30000 nM
Compound 4 gave a limit, no number; the forecaster's own chance of this, stated with the estimate: 60%; the middle value lies on the limit itself.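

In this assay, compound 2 and compound 4 each return only a limit of the assay and not a number, so no step between them can be read: the limit of > 30000 nM in this assay, at which 2 of the 4 values shown sit.

The compounds shown leave open whether the hydroxy to methoxy change moves the number from compound 2 to compound 4, and by how much.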